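This account rests on a few compounds, and the source may have more. Where it says the series, first, only, none or still open, it means among the compounds named here.

Compound 1 `COCCc1nc2nc(C)cc(Nc3ccc(S(F)(F)(F)(F)F)cc3)n2n1`: 87.7%
Compound 2 `CCc1nc2nc(C)cc(Nc3cccc(Cl)c3)n2n1`: 86.7%

Both values come from an ADME assay on a cell-free system (plasma, Homo sapiens) for protein binding. Compound 1 gives 87.7% and compound 2 gives 86.7%. These two results lie within the scatter of each other, so neither compound can be ranked above the other. Among the compounds with values here, compound 1 therefore stands level with the only other measured compound, with most of it bound and a modest part free.

Compound 3 `Cc1cc(Nc2ccc(S(F)(F)(F)(F)F)cc2)n2nc(C3CC3)nc2n1` has not yet been measured. It carries cyclopropyl in place of 2-methoxyethyl on an aromatic carbon. The swap takes place on a five-membered aromatic ring with 3 nitrogen, between two ring nitrogen atoms, and a ring of carbon only replaces a chain that holds oxygen.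

Within the data shown here, no measured pair shows this swap on its own, so the data offer no step size to borrow. The expectation rests on the structural change alone, starting from compound 1 at 87.7%: a small move towards more binding, possibly no larger than the scatter. The expected change is a 1.5-fold lower unbound fraction from compound 1 to compound 3 (0.19 log units; within the scatter). For compound 3 the estimate is 92%, with an expected range from 85% to 97%.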

Compound 3, plasma protein binding: 97.7%
For compound 3 the middle estimate is 3.5-fold (0.54 log units) (unbound fraction) above the measured one; measured number outside the range, above it.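

In this assay, the 2-methoxyethyl place on the five-membered aromatic ring with 3 nitrogen proves able to shift binding: cyclopropyl in place of 2-methoxyethyl gives a 5.3-fold lower unbound fraction from compound 1 to compound 3 (0.73 log units; beyond the scatter). Within the data shown here, the earlier compounds differ in more than one place, whereas this pair offers the first single change that can be read, and the step lies beyond the usual scatter of repeated measurements. The swap removes a chain that holds oxygen and a hydrogen-bond acceptor and brings in a three-membered ring of carbon only, but nothing measured here explains why the unbound fraction falls.

This one swap changes the oxygen, the ring and the count of heavy atoms together, and the compounds shown do not separate these differences or say which of them matters for the shift. A plain propyl chain, a cyclobutyl ring or an amine at this same place could begin to separate them, and the size of the step on any other core of this kind also remains an open question.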